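The source may report more compounds than this note shows. Statements on the series, on what has been measured and on what is new or still open speak of the compounds shown alone.

Of the compounds shown here, three built on one shared core have been measured in an ADME assay on microsomes from liver (Mus musculus, strain CD-1) for metabolic stability, read by LC-MS, with a stated time of 60 min, tested at 20 uM; on this read-out higher numbers stand for a longer-lived compound and lower numbers for a shorter-lived compound. Compound 1 `COc1cccc(C(C)Sc2nc3c(cnn3C)c(=O)n2-c2ccccc2)c1` gives 0.1 h, compound 2 `CC(Sc1nc2c(cnn2C)c(=O)n1-c1ccccc1)c1cccnc1` gives 0.117 h, and compound 3 `Cn1ncc2c(=O)n(-c3ccccc3)c(SCc3cccc(F)c3)nc21` gives 0.133 h. Compound 3 thus stands level with the other two, as its value lies within the scatter of both.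

Compound 4 `CC(Sc1nc2c(cnn2C)c(=O)n1-c1ccccc1)c1cncnc1` has not yet been measured. It differs from compound 3 at one place, on a sulfur whose other neighbour is an aromatic carbon: 1-(pyrimidin-5-yl)ethyl in place of 3-fluorobenzyl on a sulfur. In words, 1-(pyrimidin-5-yl)ethyl stands in place of 3-fluorobenzyl.

Among the measured compounds shown here, two measured steps bear on this change. The first, a 1.2-fold higher number from compound 1 to compound 2 (0.07 log units; within the scatter), put pyridin-3-yl in place of 3-methoxyphenyl on the chain carbon. The second, a 1.1-fold higher number from compound 2 to compound 3 (0.06 log units; within the scatter), is the nearer precedent, since it exchanged 1-(pyridin-3-yl)ethyl for 3-fluorobenzyl on the same sulfur. For the measured compounds named here, the new step runs the opposite way, and no compound with pyrimidin-5-yl has yet been measured. Both measured steps stayed within the scatter, so no shift beyond the scatter is expected in this assay, although the evidence is thin.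

The expected step is a 1.1-fold higher number from compound 3 to compound 4 (0.02 log units; within the scatter). For compound 4 the estimated half-life is 0.14 h, with an expected range from 0.08 h to 0.3 h.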

Compound 4, half-life in the Mus musculus assay: 0.133 h
Compound 4: middle estimate off by 1.1-fold (0.02 log units), on the high side, and the stated range covers the measured number.
By their numbers in the Mus musculus assay, from the lowest: compounds 1, 2, 3 and 4 (each within the scatter of the next).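

In the Mus musculus assay the half-life does not respond to this position: on the sulfur, 1-(pyrimidin-5-yl)ethyl in place of 3-fluorobenzyl gives no change at the digits printed from compound 3 to compound 4 (within the scatter), and pyrimidin-5-yl on the chain carbon gives a 1.1-fold higher number from compound 2 to compound 4 (0.06 log units; within the scatter) and a 1.3-fold higher number from compound 1 to compound 4 (0.12 log units; within the scatter). Among the compounds shown here, what the earlier compounds did not show is that the same change on the sulfur, with no change in half-life, goes with a large difference in a physicochemical assay for solubility, using the shake flask method, in phosphate buffer, with a stated time of 24 h, at pH 7.4; on this read-out lower numbers stand for lower solubility and higher numbers for higher solubility: the measured solubility of compound 3, < 700 nM, and of compound 4, 264000 nM, an at least 370-fold higher number (2.57 log units; beyond the scatter) The size of that difference has an open end, since in the physicochemical assay compound 3 gives < 700 nM, which is a limit of the assay and not a number. In the physicochemical assay compound 4 gives 264000 nM, a measured number.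

The compounds shown leave open whether the pyrimidin-5-yl ring or the ethyl chain of 1-(pyrimidin-5-yl)ethyl carries the difference in the physicochemical assay, since the step from compound 3 to compound 4 exchanges both at once. They also leave open whether a group of another kind on the sulfur, such as an amine or a carboxylic acid in place of 1-(pyrimidin-5-yl)ethyl, would move the number in the Mus musculus assay beyond the scatter.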